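A few compounds are considered here, and "the series" means these few. Any claim that something is new, unique, unknown or untested is made for them only; others in the source may bear on it.

Compound 1 `CCn1c(C(=O)NCCCN(C)C)ccc1C(CC)(CC)c1ccc(OCCC(O)(CC)CC)c(C)c1`: 490 nM
Compound 2 `CCN(CC)CCNC(=O)c1ccc(C(CC)(CC)c2ccc(OCCC(O)(CC)CC)c(C)c2)n1CC`: 1630 nM
Compound 3 `C=CCN(C)C(=O)c1ccc(C(CC)(CC)c2ccc(OCCC(O)(CC)CC)c(C)c2)n1CC`: > 50000 nM, a limit of the assay

All three were read in a functional assay on Caco-2 cells (Homo sapiens) for antiproliferative activity, read by MTT assay, with a stated time of 48 h; a higher number here means a weaker inhibitor, a lower number a stronger inhibitor. Of the two actual numbers there, the higher belongs to compound 2 at 1630 nM. The gap to its nearest neighbour is a 3.3-fold higher number from compound 1 to compound 2 (0.52 log units; beyond the scatter).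

The compound still unread, compound 4 `C#CC(C)OC(=O)c1ccc(C(CC)(CC)c2ccc(OCCC(O)(CC)CC)c(C)c2)n1CC`, carries (1-methylprop-2-yn-1-yl)oxy in place of (2-(diethylamino)ethyl)amino on a carbonyl carbon. Among the compounds with values here, the closest precedent is the loss of that same group when allyl(methyl)amino enters, a large step of an at least 30-fold higher number from compound 2 to compound 3 (1.48 log units; beyond the scatter). The step of an at least 100-fold higher number from compound 1 to compound 3 (2.00 log units; beyond the scatter) is also large and likewise removes the chain holding the dialkylamino end. By contrast, the modest step of a 3.3-fold higher number from compound 1 to compound 2 (0.52 log units; beyond the scatter) keeps such a chain, and compound 4 has none. A large step is therefore expected in this assay, towards a higher number and weaker inhibition, possibly reaching the limit of the assay. The expected change is a 25-fold higher number from compound 2 to compound 4 (1.39 log units; beyond the scatter). For compound 4 the estimated value is 40000 nM, with an expected range of 8000 nM to 100000 nM.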

Compound 4, half-maximal inhibitory concentration: > 50000 nM
Compound 4: no number, only a limit; the forecaster's own chance of this, stated with the estimate: 60%; middle value at least 1.2-fold (0.09 log units) away from the limit.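

On the carbonyl carbon, (1-methylprop-2-yn-1-yl)oxy in place of (2-(diethylamino)ethyl)amino gives an at least 30-fold higher number from compound 2 to compound 4 (1.48 log units; beyond the scatter) in this assay, and the comparison with the propyl chain gives an at least 100-fold higher number from compound 1 to compound 4 (2.00 log units; beyond the scatter). The loss seen with allyl(methyl)amino is therefore not confined to that one amide: a group joined through oxygen, carrying a triple bond and no dialkylamino end, falls just as far within the range this assay can read. Compound 4, like compound 3, stands at a limit and not at a number, so the step between these two cannot be read: the limit of > 50000 nM in this assay, at which 2 of the 4 values shown sit.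

On these data alone, it remains open whether the terminal amine or the amide nitrogen matters more. An ester carrying the same 2-(diethylamino)ethyl chain, or a plain butyl amide without a terminal amine, would separate the two.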